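Benzyl for 4-aminocyclohexyl: compound 1 to compound 4

The compounds below may be only part of what the source reports. "The series", "measured", "known", "first", "only" and "open" are said of these compounds alone.

In a functional assay on HCT-116 cells (Homo sapiens) for cytotoxicity, read by MTT assay, with a stated time of 72 h (on this read-out lower numbers stand for stronger inhibition and higher numbers for weaker inhibition), compound 1 (`N[C@H]1CC[C@H](Nc2c(C(=O)NCc3ccc(F)cc3)nc(Br)c3cccnc23)CC1`) gives 7000 nM and compound 2 (`N[C@H]1CC[C@H](Nc2c(C(=O)NCc3ccc(Cl)cc3Cl)nc(Br)c3cccnc23)CC1`) gives 6000 nM while compound 3 (`N[C@H]1CC[C@H](Nc2c(C(=O)NCc3ccc(Cl)cc3)nc(Br)c3cccnc23)CC1`) gives 4000 nM so compound 1 lies within the scatter of both others. The measured steps, a 1.2-fold lower number from compound 1 to compound 2 (0.07 log units; within the scatter) and a 1.8-fold lower number from compound 1 to compound 3 (0.24 log units; within the scatter) and a 1.5-fold lower number from compound 2 to compound 3 (0.18 log units; within the scatter) (all within the scatter), only alter the aryl group on the amide side. Compound 4 (`O=C(NCc1ccc(F)cc1)c1nc(Br)c2cccnc2c1NCc1ccccc1`) instead carries benzyl in place of 4-aminocyclohexyl on a nitrogen on an aromatic ring. No measured step sizes this change, so only a tentative shift toward a higher number is expected, an estimated 1.4-fold higher number from compound 1 to compound 4 (0.15 log units; within the scatter) with wide uncertainty. For compound 4 the estimated value is 10000 nM with 3000 nM to 35000 nM as the expected range.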

Compound 4, half-maximal inhibitory concentration: > 20000 nM
Compound 4: only a limit was reported; the forecaster's own chance of this, stated with the estimate: 25%; at least 2.0-fold (0.30 log units) between middle value and limit.
By their numbers in this assay, from the lowest: compounds 3, 2 and 1 (each within the scatter of the next). At a limit, above all of these: compound 4.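

In this assay, going by these compounds alone, (4-aminocyclohexyl)amino to benzylamino gives the first step that lies beyond the scatter: an at least 2.8-fold higher number from compound 1 to compound 4 (0.45 log units; beyond the scatter). Within the data shown here, the aryl changes on the amide side, compounds 1, 2 and 3, gave only steps within the scatter, so this position on the shared core is the first place where a change registers in this read-out. Compound 4 is reported only as a limit: the limit of > 20000 nM in this assay, at which 1 of the 4 values shown sits.

Benzyl removes the amine and the non-aromatic ring together, and the compounds shown do not separate the two. Cyclohexyl without the amine would be the direct comparison.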